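Compound 2 to compound 3: hydrogen for trifluoromethyl

The source may report more compounds than this note shows. Statements on the series, on what has been measured and on what is new or still open speak of the compounds shown alone.

compound 1 `N#Cc1ccc(O[C@H]2CN(S(=O)(=O)c3ccc(C(F)(F)F)cc3)C[C@@]2(O)CO)cc1F`: 5.9 L/kg
compound 2 `N#Cc1ccc(O[C@H]2CN(S(=O)(=O)c3ccc(C(F)(F)F)cc3C#N)C[C@@]2(O)CO)cc1F`: 3.6 L/kg
compound 3 `N#Cc1ccc(O[C@H]2CN(S(=O)(=O)c3ccccc3C#N)C[C@@]2(O)CO)cc1F`: not yet measured

In an ADME assay on the whole organism (Rattus norvegicus, strain Sprague-Dawley) for pharmacokinetics, read by LC-MS, with a stated time of 30 min (on this read-out lower numbers stand for narrower distribution and higher numbers for wider distribution into tissues), compound 2 stands at 3.6 L/kg and compound 1 at 5.9 L/kg on the same read-out. Among the measured compounds shown here, the one measured step is a 1.6-fold lower number from compound 1 to compound 2 (0.21 log units; within the scatter) and it stays within the scatter, so these two values cannot be separated.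

Compound 3 keeps the rest of compound 2 and carries hydrogen in place of trifluoromethyl on an aromatic carbon, meta to a cyano group and para to a large group: hydrogen in place of trifluoromethyl on an aromatic carbon.

For the measured compounds named here, no measured pair shows trifluoromethyl leaving. Going by the values given here, the only guide is a 1.6-fold lower number from compound 1 to compound 2 (0.21 log units; within the scatter) for cyano in place of hydrogen on an aromatic carbon, which is a different change and a weak precedent. On that thin basis, no step beyond the scatter is expected in this assay and no firm direction can be given. The expected step is a 1.2-fold lower number from compound 2 to compound 3 (0.08 log units; within the scatter) on this estimate. For compound 3 the estimated value is 3 L/kg with an expected range from 1.3 L/kg to 6.5 L/kg on this read-out.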

Compound 3, volume of distribution at steady state in the Rattus norvegicus assay: 0.9 L/kg
Beside the measured number, compound 3's estimate is 3.3-fold (0.52 log units) above it, outside the stated range (below it).
By their numbers in the Rattus norvegicus assay, from the lowest: compound 3; then compounds 2 and 1 (each within the scatter of the next).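

In the Rattus norvegicus assay compound 2 gives 3.6 L/kg and compound 3 gives 0.9 L/kg; hydrogen in place of trifluoromethyl gives a 4.0-fold lower number from compound 2 to compound 3 (0.60 log units; beyond the scatter), whereas cyano in place of hydrogen on an aromatic carbon gives a 1.6-fold lower number from compound 1 to compound 2 (0.21 log units; within the scatter). In the Rattus norvegicus assay the full exchange of 4-(trifluoromethyl)phenyl for 2-cyanophenyl on the sulfonyl sulfur gives a 6.6-fold lower number from compound 1 to compound 3 (0.82 log units; beyond the scatter) and is also beyond the scatter, so distribution in this series responds to what sits on this aromatic carbon, para to a large group. In a physicochemical assay for solubility, in simulated intestinal fluid, with a stated time of 4 h (on this read-out lower numbers stand for lower solubility and higher numbers for higher solubility), compound 2 gives 25 ug/mL and compound 3 gives 20 ug/mL; the same hydrogen for trifluoromethyl change gives a 1.3-fold lower number from compound 2 to compound 3 (0.10 log units; within the scatter) and stays within the scatter there, so among these compounds the two read-outs do not move together, and no measurement at hand explains the step in distribution.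

Among the compounds shown here, still open is whether the step depends on the cyano group shared by compound 2 and compound 3, since no pair shows trifluoromethyl leaving without it. Also open, going by these compounds, is where a methyl group, a chlorine atom or an amine on the same aromatic carbon would fall relative to hydrogen and trifluoromethyl, in distribution and in solubility.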